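Notes on the quinazoline-free comparison of compounds 2 and 3

The source may hold more compounds than are shown below. What is called first, only, known or untested is meant among the compounds shown, and "the series" means these compounds.

Two members of the series have numbers in a functional assay on MCF7 cells (Homo sapiens) for antiproliferative activity, read by sulforhodamine B assay, with a stated time of 72 h; on this read-out higher numbers stand for weaker inhibition and lower numbers for stronger inhibition. Compound 1 `COc1ncc(-c2ccc3ncnc(Nc4cnn(CCC(=O)O)c4)c3c2)cc1NS(C)(=O)=O` gives 560 nM in this assay. Compound 2 `COc1ncc(-c2ccc3ncnc(Nc4ccc(OCCO)c(F)c4)c3c2)cc1NS(=O)(=O)c1ccc(F)cc1F` gives 4820 nM in this assay and stands as the higher of the two numbers, its gap to compound 1 lying beyond the scatter. Compound 3 `COC(=O)Cn1cc(Nc2ncnc3ccc(-c4cnc(OC)c(NS(=O)(=O)c5ccc(F)cc5F)c4)cc23)cn1` differs from compound 2 in one place: 1-((methoxycarbonyl)methyl)-1H-pyrazol-4-yl in place of 3-fluoro-4-(2-hydroxyethoxy)phenyl on a nitrogen on an aromatic ring. Going by the values given here, no measured pair shows this exact change, so the size of the step is unknown. The expectation for the step from compound 2 to compound 3 in this assay is a fall, a 5.4-fold lower number from compound 2 to compound 3 (0.73 log units; beyond the scatter), with the direction set mainly because compound 1 gives 560 nM in this assay, compound 1 being the other member with a related substituent on that nitrogen. For compound 3 the estimate in this assay is 900 nM, with a range from 300 nM to 3000 nM.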

Compound 3, half-maximal inhibitory concentration: 670 nM
Compound 3: the middle estimate sits 1.3-fold (0.13 log units) above what was measured, within the range that was stated.
By their numbers in this assay, from the lowest: compounds 1 and 3 (each within the scatter of the next); then compound 2.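

Going by these compounds alone, exchanging 3-fluoro-4-(2-hydroxyethoxy)phenyl for 1-((methoxycarbonyl)methyl)-1H-pyrazol-4-yl on a nitrogen on an aromatic ring gives, in this assay, a 7.2-fold lower number from compound 2 to compound 3 (0.86 log units; beyond the scatter), the only single-place step available, so this position does affect the read-out with the rest of compound 2 held constant. The change replaces the six-membered aromatic ring of carbon only with a five-membered aromatic ring with 2 hetero atoms, and it also exchanges the side groups, so the step cannot be assigned to any one of these parts. Nothing available bears on the cause of the step.

Going by these compounds, it remains open whether the ring or the side chain carries the step. A carboxylic acid in place of the methyl ester on the pyrazole, or a 2-hydroxyethoxy chain on the same pyrazole, would separate the two.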